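Amino in Place of Methoxy on a Shared Core

The source may report more compounds than this note shows. Statements on the series, on what has been measured and on what is new or still open speak of the compounds shown alone.

In an assay on HEK293 cells for inhibition of acid ceramidase (Homo sapiens), read by fluorescence, with stated times of 30 min and 1 h (on this read-out higher numbers stand for weaker inhibition and lower numbers for stronger inhibition), compound 2 `COc1nc2ccccc2n1C(=O)NCCCCc1ccccc1` gives 13.9 nM, the higher of the two numbers recorded, while compound 1 `CCCCCCNC(=O)n1c(N)nc2ccccc21` gives 2.4 nM, and the gap between them lies beyond the usual scatter. Compound 3 `Nc1nc2ccccc2n1C(=O)NCCCCc1ccccc1` has not yet been measured. It differs from compound 2 by amino in place of methoxy on an aromatic carbon. For compound 3 a step toward stronger inhibition is expected, of the size a 3.5-fold lower number from compound 2 to compound 3 (0.54 log units; beyond the scatter) in this assay, since compound 1 with the same amino group gives 2.4 nM. Compound 3 is estimated at 4 nM, with a range from 1.5 nM to 12 nM.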

Compound 3, half-maximal inhibitory concentration in the acid ceramidase assay: 0.9 nM
For compound 3 the middle estimate is 4.4-fold (0.65 log units) above the measured one, outside the stated range (below it).
By their numbers in the acid ceramidase assay, from the lowest: compound 3; then compound 1; then compound 2.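

In the acid ceramidase assay amino in place of methoxy on this aromatic carbon gives a 15-fold lower number from compound 2 to compound 3 (1.19 log units; beyond the scatter), and phenyl in place of ethyl on the chain gives a 2.7-fold lower number from compound 1 to compound 3 (0.43 log units; beyond the scatter), so compound 3 is the strongest inhibitor of the three. In a physicochemical assay for metabolic stability, read by HPLC, in phosphate buffer, at pH 7.4, tested at 10 uM (a lower number here means that the compound disappears faster, a higher number that the compound lasts longer), compound 2 gives > 2 h, which is a limit of the assay and not a number. In the physicochemical assay compound 3 gives 0.233 h, which makes the same change an at least 8.5-fold lower number from compound 2 to compound 3 (0.93 log units; beyond the scatter), a step open at one end: the limit of > 2 h in the physicochemical assay, at which 1 of the 2 values shown sits.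

The compounds shown leave open whether another group on this carbon, such as methylamino or hydroxyl, would keep the strong inhibition and also the longer half-life.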